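Aryl chloro to methoxy exchange in a shared series

The source may report more compounds than this note shows. Statements on the series, on what has been measured and on what is new or still open speak of the compounds shown alone.

Measured so far in a functional assay on A549 cells (Homo sapiens) for antiproliferative activity, read by MTT assay, with a stated time of 48 h; on this read-out higher numbers stand for weaker inhibition and lower numbers for stronger inhibition:
compound 1 `O=c1c(-c2ccc(Cl)cc2)cn(C2CC2)c2cc(N3CCNCC3)c(F)cc12`, 650 nM
compound 2 `COc1ccc(-c2cn(C3CC3)c3cc(N4CCNCC4)c(F)cc3c2=O)cc1`, 1870 nM
compound 3 `CN1CCN(c2cc3c(cc2F)c(=O)c(-c2cccc(Cl)c2)cn3C2CC2)CC1`, 1340 nM

Compound 1 to compound 2 carries methoxy in place of chloro on an aromatic carbon and gave a 2.9-fold higher number from compound 1 to compound 2 (0.46 log units; beyond the scatter). Compound 3 and compound 1 differ in more than one place; the difference between the two cores is not broken down here. Compound 4 `COc1cccc(-c2cn(C3CC3)c3cc(N4CCN(C)CC4)c(F)cc3c2=O)c1`, not yet measured, carries methoxy in place of chloro on an aromatic carbon. The place is not identical: in compound 1 the group sits para to a large group, in compound 3 meta to a large group, so this is the same kind of change rather than the same change. For the measured compounds named here, with the single earlier occurrence as the only guide, compound 4 is expected to show a 2.5-fold higher number from compound 3 to compound 4 (0.39 log units; beyond the scatter), set beside a 2.9-fold higher number from compound 1 to compound 2 (0.46 log units; beyond the scatter) and widened for the changed place. In this assay compound 4 is thus estimated at 3300 nM, expected to fall between 1500 nM and 7500 nM.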

Compound 4, half-maximal inhibitory concentration: 1120 nM
Estimate against measurement, compound 4: 2.9-fold (0.47 log units) above, outside the stated range (below it).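

In this assay, exchanging chloro for methoxy on the core of compound 3 gave a 1.2-fold lower number from compound 3 to compound 4 (0.08 log units; within the scatter), so the step seen on the other core does not reappear here. The exchange therefore cannot be carried from one core to the other at a fixed size: the same change on two cores in this assay, a 2.9-fold higher number (0.46 log units; beyond the scatter) from compound 1 to compound 2 and a 1.2-fold lower number (0.08 log units; within the scatter) from compound 3 to compound 4, 3.4-fold (0.54 log units) apart, beyond the scatter of two such steps

The two cores differ in more than one place and the group does not sit in the same place on both, so these two steps do not separate those differences and give no rule for the series.

Open, from the compounds shown here alone, is how the exchange reads with the group in the same place on both cores. Also open, going by these compounds, is how other groups on that aromatic ring, such as a nitrile or an amine, read in this assay.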